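Three uracil derivatives at the assay limit, one more to come

A few compounds are considered here, and "the series" means these few. Any claim that something is new, unique, unknown or untested is made for them only; others in the source may bear on it.

Compound 1 `COCn1c(CC(O)(COCc2ccccc2)COCc2ccccc2)cc(=O)[nH]c1=O`: > 100000 nM
Compound 2 `C[Si](C)(C)CCOCn1c(CC(O)(COCc2ccccc2)COCc2ccccc2)cc(=O)[nH]c1=O`: > 100000 nM
Compound 3 `Cc1c(CC(O)COCc2ccccc2)n(COCC[Si](C)(C)C)c(=O)[nH]c1=O`: > 100000 nM

In a functional assay on HeLa cells (Homo sapiens) for antiproliferative activity, read by MTT assay, with a stated time of 72 h (a higher number here means a weaker inhibitor, a lower number a stronger inhibitor), compound 1 gives > 100000 nM, which is a limit of the assay and not a number. In this assay compound 2 gives > 100000 nM, again a limit. In this assay compound 3 gives > 100000 nM, also a limit.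

Compound 2 and compound 1 differ in one place: a hydrogen atom in place of a group of 5 heavy atoms (4 carbon, 1 silicon; no ring), on a saturated chain carbon bound to an oxygen on a saturated carbon. The step that the two limits leave unreadable from compound 2 to compound 1 cannot be read, since both ends are limits. The difference between the cores of compound 2 and compound 3 is not broken down here.

Compound 4 `COCn1c(CC(O)COCc2ccccc2)c(C)c(=O)[nH]c1=O` has not yet been measured. It differs from compound 3 by a hydrogen atom in place of a group of 5 heavy atoms (4 carbon, 1 silicon; no ring), on a saturated chain carbon bound to an oxygen on a saturated carbon, the same change that takes compound 2 to compound 1, made at the same place. Going by the values given here, since every measured value sits at the limit of > 100000 nM in this assay, at which 3 of the 3 values shown sit, there is no measured step that tells how large this change is.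

The step that the limit leaves unreadable from compound 3 to compound 4 is expected to be flat, resting on compound 3 and its limit > 100000 nM and on the fact that three of three values sit at the limit of > 100000 nM in this assay, at which 3 of the 3 values shown sit. Compound 4 is therefore expected to give about 200000 nM in this assay, most likely again reported only as a limit, with a range from 100000 nM to 1000000 nM.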

Compound 4, half-maximal inhibitory concentration: > 100000 nM
Compound 4 was reported as a limit; the forecaster's own chance of this, stated with the estimate: 85%; the middle value does not contradict the limit.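

No new step can be read: compound 3 and compound 4 are both reported only as limits, and the change from one to the other cannot be given a size. The compounds shown leave open how much this change matters in this assay, and whether any compound of this series gives a real number there, since all of them stand at one value: the limit of > 100000 nM in this assay, at which 4 of the 4 values shown sit.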